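A few compounds are considered here, and "the series" means these few. Any claim that something is new, unique, unknown or untested is made for them only; others in the source may bear on it.

Measured compounds:
Compound 1, `N#C/C(=C\c1ccccc1OS(=O)(=O)c1ccc(Cl)cc1)C(=O)Nc1nnc(Cc2ccccc2)s1`, gives 73% in a functional assay on RS4-11 cells (Homo sapiens) for inhibition, read by CCK-8 assay, with a stated time of 48 h, tested at 20 uM; on this read-out higher numbers stand for more inhibition of growth at the one concentration tested and lower numbers for less inhibition of growth.
Compound 2, `N#C/C(=C\c1ccccc1OS(=O)(=O)c1ccc(F)cc1)C(=O)Nc1nnc(Cc2ccccc2)s1`, gives 69% in this assay.
Compound 3, `N#C/C(=C\c1ccccc1OS(=O)(=O)c1ccc(Cl)cc1)C(=O)Nc1nnc(Cc2ccc(F)cc2)s1`, gives 68% in this assay.

The three measured compounds share one core and differ only in two halogen positions. Compound 2 differs from compound 1 by fluoro in place of chloro on an aromatic carbon, and in this assay that change gave a number 4 percentage points lower from compound 1 to compound 2 (within the scatter). Compound 3 differs from compound 1 by fluoro in place of hydrogen on an aromatic carbon, and that change gave a number 5 percentage points lower from compound 1 to compound 3 (within the scatter). Going by the values given here, no step is worked out between compound 2 and compound 3; their two values lie within the usual scatter of each other, and all three compounds sit in the same band.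

Compound 4, `N#C/C(=C\c1ccccc1OS(=O)(=O)c1ccc(F)cc1)C(=O)Nc1nnc(Cc2ccc(F)cc2)s1`, has not yet been measured in this assay. It differs from compound 3 by fluoro in place of chloro on an aromatic carbon. Among the compounds with values here, this is the same change as the one from compound 1 to compound 2, made at the same place, so the step from compound 1 to compound 2 is the only guide available. Since that step was a number 4 percentage points lower from compound 1 to compound 2 (within the scatter), a step of about a number 4 percentage points lower from compound 3 to compound 4 (within the scatter) is expected from compound 3 to compound 4. On this basis compound 4 is estimated to give 64% in this assay, with the estimate expected to fall between 55% and 73%.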

Compound 4, percent growth inhibition at one concentration: 59%
Compound 4: middle estimate off by 5 percentage points, on the high side; the range from low to high includes it.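

In this assay, fluoro in place of chloro gave a number 9 percentage points lower from compound 3 to compound 4 (within the scatter), and fluoro in place of hydrogen gave a number 10 percentage points lower from compound 2 to compound 4 (within the scatter); since both steps lie within the scatter, neither change is shown to alter growth inhibition. The fluoro-for-chloro change read alike on the two cores, with no difference beyond what two such steps can show: the same change on two cores in this assay, a number 4 percentage points lower (within the scatter) from compound 1 to compound 2 and a number 9 percentage points lower (within the scatter) from compound 3 to compound 4, 5 percentage points apart, within the scatter of two such steps. The fluoro-for-hydrogen change also read alike, but this agreement covers only these four compounds, and it shows neither that a small real effect is present nor that the change would carry to a core outside this set: the same change on two cores in this assay, a number 5 percentage points lower (within the scatter) from compound 1 to compound 3 and a number 10 percentage points lower (within the scatter) from compound 2 to compound 4, 5 percentage points apart, within the scatter of two such steps.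

The compounds shown carry only chloro, fluoro or hydrogen at these two places, so it remains open how an amine, a methoxy group or a carboxylic acid would behave there. Also open, from the compounds shown here alone, is whether a longer chain in place of the single carbon that links the outer benzene ring to the shared core would leave growth inhibition in the same band, and whether these close values would stay close across a range of concentrations.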